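The source may hold more compounds than are shown below. What is called first, only, known or untested is meant among the compounds shown, and "the series" means these compounds.

Working notes on the series. The shared core of compound 1 `FC(F)(F)Oc1ccc(-c2cc(COc3ccccc3-c3nc4ccccc4s3)on2)cc1` carries, at the far end of the molecule, an aryl group on a five-membered heteroaromatic ring. In a functional assay on MCF7 cells (Homo sapiens) for cytotoxicity, read by MTT assay, with a stated time of 24 h (on this read-out higher numbers stand for weaker inhibition and lower numbers for stronger inhibition), compound 1 gives 26600 nM. Two further members of the set have been measured. Compound 2 `Fc1ccc(-n2cc(COc3ccccc3-c3nc4ccccc4s3)nn2)cc1` gives 26200 nM, and compound 3 `FC(F)(F)C(F)(F)C(F)(F)C(F)(F)C(F)(F)C(F)(F)C(F)(F)C(F)(F)CCn1cc(COc2ccccc2-c2nc3ccccc3s2)nn1` gives 19200 nM. Compound 1 thus sits at the top of the three numbers as written, but its gaps to compound 2 and to compound 3 both fall within the scatter, so the three measurements cannot be told apart and no ordering among them can be claimed.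

The next compound, compound 4 `Cc1ccc(-c2cc(COc3ccccc3-c3nc4ccccc4s3)on2)cc1`, differs from compound 1 in one place: methyl in place of trifluoromethoxy on an aromatic carbon. For the measured compounds named here, no pair of measured compounds in this set shares this exact change, so no measured step speaks to it; what the three numbers do show is that three rather different end groups all land in the same narrow band.

On that basis the step from compound 1 to compound 4 is expected to be a 1.1-fold lower number from compound 1 to compound 4 (0.03 log units; within the scatter), with no change beyond the scatter expected in either direction. Compound 4 is estimated at 25000 nM, with a range from 10000 nM to 60000 nM.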

Compound 4, half-maximal inhibitory concentration: 27500 nM
Beside the measured number, compound 4's estimate is 1.1-fold (0.04 log units) below it, within the range that was stated.
By their numbers in this assay, from the lowest: compounds 3, 2, 1 and 4 (each within the scatter of the next).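

The replacement of 4-(trifluoromethoxy)phenyl by 4-methylphenyl now has a measured step of its own in this assay, which is a 1.0-fold higher number from compound 1 to compound 4 (0.01 log units; within the scatter). The earlier compounds shown here offered only a comparison of end groups that differ in more than one place, whereas this pair isolates the aromatic carbon para to a large group: trifluoromethoxy, with 5 heavy atoms and 1 hydrogen-bond acceptor, and methyl, with 1 heavy atom and 0 hydrogen-bond acceptors, cannot be told apart on this read-out. No measured property of these compounds bears on this result, so the step comes with no explanation.

The compounds shown leave open whether any group at this carbon, such as an amine, a carboxylic acid or a longer chain, gives a step beyond the scatter. They also leave open whether the same replacement would read alike with the aryl group on the other five-membered heteroaromatic ring, as in compound 2, since this single pair speaks only for the core of compound 1.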